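From oxan-3-yl to oxan-4-yl: a small expected shift

A few compounds are considered here, and "the series" means these few. Any claim that something is new, unique, unknown or untested is made for them only; others in the source may bear on it.

Compound 1 `NC(=O)[C@@H](CCC(F)(F)F)N(CC1COC1)S(=O)(=O)c1ccc(Cl)cc1` gives 2.5
Compound 2 `NC(=O)[C@@H](CCC(F)(F)F)N(C[C@@H]1CCCCO1)S(=O)(=O)c1ccc(Cl)cc1` gives 4.3
Compound 3 `NC(=O)[C@@H](CCC(F)(F)F)N(C[C@@H]1CCCOC1)S(=O)(=O)c1ccc(Cl)cc1` gives 3.7

In a physicochemical assay for lipophilicity, read by HPLC, measured as octanol-water partition, at pH 7.4 (on this read-out higher numbers stand for higher lipophilicity and lower numbers for lower lipophilicity), compound 3 at 3.7 stands second highest of the three, under compound 2 and over compound 1. Compound 4 `NC(=O)[C@@H](CCC(F)(F)F)N(CC1CCOCC1)S(=O)(=O)c1ccc(Cl)cc1` is still unmeasured, and oxan-4-yl in place of oxan-3-yl on a saturated chain carbon bound to a sulfonamide nitrogen sets out how it differs: oxan-4-yl in place of oxan-3-yl on a saturated chain carbon bound to a sulfonamide nitrogen. Going by the values given here, the nearest precedent, with oxan-3-yl in place of oxan-2-yl, is modest: a number 0.60 log units lower from compound 2 to compound 3 (beyond the scatter) and beyond the scatter. Both a number 1.80 log units higher from compound 1 to compound 2 (beyond the scatter) and a number 1.20 log units higher from compound 1 to compound 3 (beyond the scatter) are large but start from oxetan-3-yl and so say less here. With one close precedent, the direction is tentative, but a small further fall seems likely. The expected step is a number 0.20 log units lower from compound 3 to compound 4 (within the scatter) and would stay within the usual scatter. Compound 4 is estimated at 3.5 with an expected range of 3.1 to 3.9 on this scale.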

Compound 4, distribution coefficient: 3.5
Compound 4: middle estimate and measured number agree at the digits printed; measured number inside the range.
By their numbers in this assay, from the lowest: compound 1; then compounds 4 and 3 (each within the scatter of the next); then compound 2.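

In this assay, oxan-4-yl in place of oxan-3-yl on a saturated chain carbon bound to a sulfonamide nitrogen gives (a number 0.20 log units lower from compound 3 to compound 4 (within the scatter)), so these two rings cannot be told apart at this position. Oxan-2-yl does stand apart from oxan-4-yl (a number 0.80 log units lower from compound 2 to compound 4 (beyond the scatter)), and so does oxetan-3-yl (a number 1.00 log units higher from compound 1 to compound 4 (beyond the scatter)), leaving compound 2 clear of the other two six-membered rings. No evidence is available on what lies behind these differences.

On these data alone, how a piperidin-4-yl ring, an amine with nitrogen in place of the ring oxygen, or an all-carbon cyclohexyl ring would compare at this position remains open.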